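The compounds below may be only part of what the source reports. "The series", "measured", "known", "first", "only" and "open" are said of these compounds alone.

Measured in a functional assay on HeLa cells (Homo sapiens) for cytotoxicity, read by CCK-8 assay, with a stated time of 24 h; on this read-out higher numbers stand for weaker inhibition and lower numbers for stronger inhibition:
compound 1 `C/C(=C\c1cc(-c2ccccc2C)cs1)C(N)=O` gives 19400 nM.
compound 2 `C/C(=C\c1cc(-c2ccc(C#N)cc2)cs1)C(N)=O` gives 250 nM.
compound 3 `C/C(=C\c1cc(-c2ccc(S(C)(=O)=O)cc2)cs1)C(N)=O` gives only a limit, > 50000 nM.

Compound 3 thus stands at the edge of this assay, the point described by the limit of > 50000 nM in this assay, at which 1 of the 3 values shown sits. The change to compound 4 `C=Cc1ccc(-c2csc(/C=C(\C)C(N)=O)c2)cc1` is vinyl in place of methylsulfonyl on an aromatic carbon. Going by the values given here, the one measured step at the same place, an at least 200-fold higher number from compound 2 to compound 3 (2.30 log units; beyond the scatter), shows how far an exchange of that group can move the number. Among the compounds with values here, no measured compound carries a vinyl group, so the direction is read from compound 3 alone: from a limit the number can only come down or stay where it is. Compound 4 is therefore expected to fall within range of this assay, at an estimated 4000 nM spanning 600 nM to 25000 nM, which corresponds to the estimated step of an at least 12-fold lower number from compound 3 to compound 4 (1.09 log units; beyond the scatter).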

Compound 4, half-maximal inhibitory concentration: > 50000 nM
Compound 4 gave a limit, no number (the forecaster's own chance of this, stated with the estimate: 15%); middle value at least 12-fold (1.09 log units) away from the limit.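

With vinyl in place of cyano on the aromatic carbon, the read-out shows an at least 200-fold higher number from compound 2 to compound 4 (2.30 log units; beyond the scatter), so the large loss from cyano is not confined to the exchange for methylsulfonyl. The step between compound 3 and compound 4 cannot be read, as both values are limits. The limit now holds a second compound with a different group at this position: the limit of > 50000 nM in this assay, at which 2 of the 4 values shown sit.

On these data alone, how far compound 3 and compound 4 lie beyond that limit stays open. So does whether an amine, a carboxylic acid or a longer chain at this position would keep a value near that of compound 2, 250 nM.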